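Fluorine on the Phenyl Ring: From Compound 2 to Compound 3

The source may report more compounds than this note shows. Statements on the series, on what has been measured and on what is new or still open speak of the compounds shown alone.

Measured so far:
Compound 1 `CO[C@@H]1C[C@@H]2[C@H]([C@]1(N)C(=O)O)[C@@]2(F)C(=O)O` gives 88.1 nM in an assay on CHO cells for binding affinity to metabotropic glutamate receptor 3 (Rattus norvegicus); a higher number here means a weaker inhibitor, a lower number a stronger inhibitor.
Compound 2 `N[C@]1(C(=O)O)[C@H]2[C@@H](C[C@H]1OCc1ccccc1)[C@]2(F)C(=O)O` gives 15.9 nM in this assay.

Of the two measured numbers, compound 2 shows the lower one; the step of a 5.5-fold lower number from compound 1 to compound 2 (0.74 log units; beyond the scatter) takes it apart from compound 1 by a margin beyond the scatter. Compound 3 `N[C@]1(C(=O)O)[C@H]2[C@@H](C[C@H]1OCc1ccc(F)c(F)c1)[C@]2(F)C(=O)O` has not yet been measured. It differs from compound 2 in one place: 3,4-difluorophenyl in place of phenyl on a saturated chain carbon bound to an oxygen on a saturated carbon.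

Within the data shown here, no measured step bears directly on this change. Among the measured compounds shown here, the single step, a 5.5-fold lower number from compound 1 to compound 2 (0.74 log units; beyond the scatter), concerns the arrival of the phenyl group itself, not substitution on it, so it says nothing about what fluorine on the ring will do. In the absence of a precedent, the step of a 1.1-fold lower number from compound 2 to compound 3 (0.06 log units; within the scatter) is expected to stay within the scatter, with no clear direction. Compound 3 is therefore estimated to give 14 nM, within a range from 5 nM to 40 nM.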

Compound 3, inhibition constant: 3 nM
Compound 3: middle estimate off by 4.7-fold (0.67 log units), on the high side, outside the stated range (below it).
By their numbers in this assay, from the lowest: compound 3; then compound 2; then compound 1.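

The phenyl ring at this position is not just a passive add-on: in this assay, replacing phenyl with 3,4-difluorophenyl gives a 5.3-fold lower number from compound 2 to compound 3 (0.72 log units; beyond the scatter) and shows that substitution on the ring can still move the number once the ring is in place. Measured against the hydrogen of compound 1, the same group gives a 29-fold lower number from compound 1 to compound 3 (1.47 log units; beyond the scatter) and is the largest step seen so far at this position. No available evidence explains why the number falls.

Because both fluorines enter together, these compounds cannot separate the contribution of each one or show what a single fluorine on the ring would do. They also leave open whether chlorine, methoxy or nitrile on the ring would lower the number in the same way.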